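The source may report more compounds than this note shows. Statements on the series, on what has been measured and on what is new or still open speak of the compounds shown alone.

In this series, compound 1 `COc1cccc(C(=O)N2CCN(CC(=O)N3CCN(CCCc4c[nH]c5ccccc45)CC3)CC2)c1` is the starting point. In an ADME assay on SH-SY5Y cells (Homo sapiens) for cytotoxicity, read by MTT assay, with a stated time of 72 h (a lower number here means a stronger inhibitor, a higher number a weaker inhibitor), compound 1 reaches only the limit of > 200000 nM. Compound 2 `O=C(CN1CCN(C(=O)c2cccc(Br)c2)CC1)N1CCN(CCCc2c[nH]c3ccccc23)CC1` gives 80500 nM in this assay. The change between them is bromo in place of methoxy on an aromatic carbon, and it produced an at least 2.4-fold lower number from compound 1 to compound 2 (0.39 log units; beyond the scatter); the step is read as at least that size because compound 1 sits at the limit of > 200000 nM in this assay, at which 1 of the 3 values shown sits. Compound 3 `COc1ccc(C(=O)N2CCN(CC(=O)N3CCN(CCCc4c[nH]c5ccc(F)cc45)CC3)CC2)cc1` gives 161000 nM in this assay, a value that lies within the scatter of compound 2. How the core of compound 3 differs from the core of compound 1 is not broken down here.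

Compound 4 `O=C(CN1CCN(C(=O)c2ccc(Br)cc2)CC1)N1CCN(CCCc2c[nH]c3ccc(F)cc23)CC1` has not yet been measured. It differs from compound 3 by bromo in place of methoxy on an aromatic carbon, the same kind of change as that from compound 1 to compound 2, but here the group sits para to a large group rather than meta to it. Resting on the step seen from compound 1 to compound 2 in this assay, compound 4 is expected to show a 2.5-fold lower number from compound 3 to compound 4 (0.39 log units; beyond the scatter). The estimate for compound 4 is therefore 65000 nM, with a range from 25000 nM to 160000 nM.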

Compound 4, half-maximal inhibitory concentration: 47400 nM
The estimate for compound 4 lay 1.4-fold (0.14 log units) above the measured number; measured number inside the range.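

In this assay, bromo in place of methoxy on the second core gives a 3.4-fold lower number from compound 3 to compound 4 (0.53 log units; beyond the scatter), so the number falls on both cores shown and the change carries over in direction. Set side by side, the two steps compare as follows: the same change on two cores in this assay, an at least 2.4-fold lower number (0.39 log units; beyond the scatter) from compound 1 to compound 2 and a 3.4-fold lower number (0.53 log units; beyond the scatter) from compound 3 to compound 4; the limit leaves it open whether they differ. Among the compounds shown here, the comparison shows no more than that, as it rests on only two pairs and the earlier step is only a bound, resting on a limit: the limit of > 200000 nM in this assay, at which 1 of the 4 values shown sits.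

The compounds shown leave open how much of the step belongs to the core and how much to the place of the group, which in compound 4 is para to a large group, as the two pairs differ in both. They also leave open whether another group on that aromatic carbon, such as chloro, an amine or a carboxylic acid, would lower the number in the same way on either core.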